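Swapping trifluoromethoxy for cyano on two related cores

The compounds below may be only part of what the source reports. "The series", "measured", "known", "first", "only" and "open" are said of these compounds alone.

Measured compounds:
Compound 1, `CC(O)(COc1ccc(OC(F)(F)F)cc1)C(=O)Nc1ccc(S(F)(F)(F)(F)F)cc1`, gives 12800 nM.
Compound 2, `CC(O)(COc1ccc(C#N)cc1)C(=O)Nc1ccc(S(F)(F)(F)(F)F)cc1`, gives 100000 nM.
Compound 3, `CC(O)(COc1ccc(OC(F)(F)F)cc1)C(=O)Nc1cccc(S(F)(F)(F)(F)F)c1`, gives 20200 nM.

All three were tested in a functional assay on VCaP cells (Homo sapiens) for antiproliferative activity, read by propidium iodide staining, with a stated time of 96 h; a lower number here means a stronger inhibitor, a higher number a weaker inhibitor. Compounds 1 and 2 share one core and differ by a single change, (cyano in place of trifluoromethoxy on an aromatic carbon). That change made a step of a 7.8-fold higher number from compound 1 to compound 2 (0.89 log units; beyond the scatter), so compound 2 is the weaker of the pair. Compound 3 carries the same atoms as compound 1 joined in a different way; the difference between the two cores is not broken down here. Compound 3 and compound 1 lie within the usual scatter of each other, while compound 3 stands well apart from compound 2.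

Compound 4, `CC(O)(COc1ccc(C#N)cc1)C(=O)Nc1cccc(S(F)(F)(F)(F)F)c1`, has not yet been measured. It is related to compound 3 by cyano in place of trifluoromethoxy on an aromatic carbon, which is the same change already seen between compound 1 and compound 2. Because the earlier change gave a 7.8-fold higher number from compound 1 to compound 2 (0.89 log units; beyond the scatter), a step of about the same size is expected from compound 3 to compound 4, namely a 5.0-fold higher number from compound 3 to compound 4 (0.69 log units; beyond the scatter). Since compound 3 starts at a weaker level than compound 1, the expected value of compound 4 is estimated at 100000 nM, with a likely range from 50000 nM to 200000 nM. There is a real chance that this assay will return only a limit rather than a number for compound 4.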

Compound 4, half-maximal inhibitory concentration: 26600 nM
Estimate against measurement, compound 4: 3.8-fold (0.58 log units) above, outside the stated range (below it).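

On the core of compound 3, putting cyano in place of trifluoromethoxy gave a 1.3-fold higher number from compound 3 to compound 4 (0.12 log units; within the scatter) in this assay and so left the number within the usual scatter. The same change therefore did not carry over with the same size from one core to the other: the same change on two cores in this assay, a 7.8-fold higher number (0.89 log units; beyond the scatter) from compound 1 to compound 2 and a 1.3-fold higher number (0.12 log units; within the scatter) from compound 3 to compound 4, 5.9-fold (0.77 log units) apart, beyond the scatter of two such steps. This shows that a step measured on the core of compound 1 was a poor guide to the step on the core of compound 3, but two pairs in one assay do not explain the difference between the cores or show how the change would behave on a third core.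

On these data alone, it remains open whether other groups on the same aromatic carbon, such as an amine, a carboxylic acid or a longer chain ending in an alcohol, would give a large step on one core and a small step on the other, as cyano does. As far as these compounds go, it also remains open whether the two cores would differ in the same way for such groups, or whether this gap belongs to the exchange of trifluoromethoxy for cyano alone.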